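Swapping Amino for Bromo on the Phenoxy Ring

This account rests on a few compounds, and the source may have more. Where it says the series, first, only, none or still open, it means among the compounds named here.

Measured so far in a functional assay on MCF7 cells (Homo sapiens) for antiproliferative activity, read by MTT assay, with a stated time of 48 h; on this read-out higher numbers stand for weaker inhibition and lower numbers for stronger inhibition:
compound 1 `O=c1cc(-n2cc(COc3ccccc3)nn2)c2cc(Br)ccc2o1`: 1720 nM
compound 2 `Nc1ccc(OCc2cn(-c3cc(=O)oc4ccc(Br)cc34)nn2)cc1`: 2040 nM

Compound 2 has the higher of the two numbers, but its distance to compound 1 is small: a 1.2-fold higher number from compound 1 to compound 2 (0.07 log units; within the scatter), so the two are not distinguishable here. That single step shows that adding an amino group to the phenoxy ring of the shared core changed little.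

Compound 3 `O=c1cc(-n2cc(COc3ccc(Br)cc3)nn2)c2cc(Br)ccc2o1` differs from compound 2 by bromo in place of amino on an aromatic carbon. For the measured compounds named here, no measured step exchanges one substituent for another at this position; the only related evidence is the step from compound 1 to compound 2, which stayed within the scatter when a hydrogen became an amino group. The same position therefore appears to tolerate a change without a large shift, and the expectation for compound 3 is a step of about a 1.1-fold lower number from compound 2 to compound 3 (0.03 log units; within the scatter), not beyond the scatter. Compound 3 is thus estimated at 1900 nM, within a range of 900 nM to 4200 nM.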

Compound 3, half-maximal inhibitory concentration: 1920 nM
Estimate against measurement, compound 3: 1.0-fold (0.00 log units) below; the range from low to high includes it.
By their numbers in this assay, from the lowest: compounds 1, 3 and 2 (each within the scatter of the next).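

Bromo can stand in for amino on the phenoxy ring in this assay with no visible effect (a 1.1-fold lower number from compound 2 to compound 3 (0.03 log units; within the scatter)). Bromo in place of hydrogen likewise stays within the usual scatter (a 1.1-fold higher number from compound 1 to compound 3 (0.05 log units; within the scatter)). This position has now carried hydrogen, amino and bromo without separating the three compounds, even though amino counts one hydrogen-bond donor and one acceptor and bromo counts neither, and no supporting information is available to explain this tolerance.

On these data alone, whether the position would stay this tolerant with a carboxylic acid, a nitrile or a longer chain such as butoxy remains open. Also open, as far as these compounds go, is how the number would respond to changes elsewhere on the shared core, since the parts outside this position are the same in all three compounds.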